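The source may hold more compounds than are shown below. What is called first, only, known or untested is meant among the compounds shown, and "the series" means these compounds.

Measured compounds:
compound 1 `Nc1scc(-c2cccc(F)c2)c1C(=O)c1ccccc1` — 51%
compound 2 `Nc1scc(-c2ccc(Cl)cc2)c1C(=O)c1ccccc1` — 46%
compound 3 `Nc1scc(-c2cccc(Br)c2)c1C(=O)c1ccccc1` — 67%

In a functional assay on CHO cells for agonist activity at adenosine receptor A1 (Homo sapiens), read by fluorescence and ERK phosphorylation, with stated times of 30 min and 1.5 h, tested at 3 uM (a lower number here means a weaker effect, a higher number a stronger effect of the compound at the concentration tested), compound 2 gives 46%, the lowest of the three numbers. The step of a number 5 percentage points lower from compound 1 to compound 2 (within the scatter) is within the scatter, so compound 1 and compound 2 cannot be ordered; the step of a number 21 percentage points higher from compound 2 to compound 3 (beyond the scatter) is beyond it, and so is a number 16 percentage points higher from compound 1 to compound 3 (beyond the scatter) between the two compounds that share the ring position of the halogen.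

Compound 4 `COc1ccc(-c2csc(N)c2C(=O)c2ccccc2)cc1` differs from compound 2 by methoxy in place of chloro on an aromatic carbon.

None of the three measured steps bears directly on this change: each exchanges one halogen for another, and none introduces methoxy. The two steps beyond the scatter both move toward bromo, which compound 4 lacks. The step from fluoro to chloro with a change of ring position stayed within the scatter. The data therefore give no ground for a step beyond the scatter in this assay in either direction, and a number near that of compound 2 is expected, with wide uncertainty. This expectation corresponds to a step of a number 1 percentage points lower from compound 2 to compound 4 (within the scatter). For compound 4 the estimated value in this assay is 45%, with a range of 25% to 65%.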

Compound 4, a percentage reported as activity, at one concentration (the size of the read-out at that concentration, not a potency): 52%
Estimate against measurement, compound 4: 7 percentage points below; the measured number falls inside the stated range.
By their numbers in this assay, from the lowest: compounds 2, 1 and 4 (each within the scatter of the next); then compound 3.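

In this assay, among these compounds, the first exchange of a halogen for a group that is not a halogen, methoxy in place of chloro on an aromatic carbon para to a large group, gives a number 6 percentage points higher from compound 2 to compound 4 (within the scatter). The larger group, which also counts as a hydrogen-bond acceptor where chloro does not, therefore leaves the read-out unchanged within the usual scatter at this place, so this position is not limited to halogens in this assay. No measurement at hand gives a reason for this result.

Open, on these data alone, is whether an amine or a carboxylic acid on the same aromatic carbon would move the number beyond the scatter. Also open, as far as these compounds go, is whether compound 2 and compound 4 would still match in potency, since a read-out at a single concentration does not give one.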